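This account rests on a few compounds, and the source may have more. Where it says the series, first, only, none or still open, it means among the compounds named here.

Two compounds of the series have been run in a functional assay on HeLa cells (Homo sapiens) for antiproliferative activity, read by MTT assay, with a stated time of 72 h (on this read-out lower numbers stand for stronger inhibition and higher numbers for weaker inhibition), so far. Compound 1, `COc1cc(-c2ncnn2-c2ccc(Cl)cc2Cl)cc(OC)c1OC`, gives only a limit in this assay, > 10000 nM. Compound 2, `COc1cc(-n2ncnc2-c2ccc(Cl)cc2)cc(OC)c1OC`, likewise gives only a limit in this assay, > 10000 nM. Both measured values thus sit at the same boundary of the assay: the limit of > 10000 nM in this assay, at which 2 of the 2 values shown sit. Among the measured compounds shown here, no step between measured compounds can be read from these two values, and no pair among them differs in one place alone.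

Compound 3, `COc1cc(-n2ncnc2-c2ccc(F)cc2)cc(OC)c1OC`, is the next compound for this assay. It differs from compound 2 in a single place: fluoro in place of chloro on an aromatic carbon. For the measured compounds named here, the change is a small one, and with both measured compounds standing at a limit there is no step from which its size or direction could be read. For compound 3 the expectation is a step from compound 2 of none beyond the scatter, a step that the limit leaves unreadable from compound 2 to compound 3. Compound 3 is accordingly expected to fall at 15000 nM, within a range from 5000 nM to 50000 nM, and is expected most likely to return only a limit once more in this assay.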

Compound 3, half-maximal inhibitory concentration: > 10000 nM
Compound 3: no number, only a limit; the forecaster's own chance of this, stated with the estimate: 80%; the middle value lies beyond the limit too.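

Compound 2 and compound 3 both return only a limit in this assay, and no step between them can be read: the limit of > 10000 nM in this assay, at which 3 of the 3 values shown sit.

The compounds shown leave open whether any compound of this series gives a measurable value in this assay, and how 4-chlorophenyl and 4-fluorophenyl compare once numbers can be read.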